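This account rests on a few compounds, and the source may have more. Where it says the series, first, only, none or still open, it means among the compounds named here.

Of the compounds shown here, three built on one shared core have been measured in an assay on HEK293 cells for inhibition of kynurenine 3-monooxygenase (Homo sapiens), read by LC-MS, with a stated time of 20 h; a higher number here means a weaker inhibitor, a lower number a stronger inhibitor. Compound 1 `COCCOc1cc2oc(=O)n(CCC(=O)O)c2cc1Cl` gives 50100 nM. Compound 3 `O=C(O)CCn1c(=O)oc2cc(OCC3CC3)c(Cl)cc21` gives 1580 nM, the second highest of the three numbers. Compound 2 `C[C@@H](Oc1cc2oc(=O)n(CCC(=O)O)c2cc1Cl)c1ccc(F)cn1` gives 25.1 nM, the lowest of the three. Within the data shown here, the only step between measured compounds that differ in a single place runs from compound 1 to compound 3: a 32-fold lower number from compound 1 to compound 3 (1.50 log units; beyond the scatter).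

Compound 4 `C[C@@H](Oc1cc2oc(=O)n(CCC(=O)O)c2cc1Cl)c1ncccn1` has not yet been measured in this assay. It differs from compound 3 in that (a group of 8 heavy atoms (6 carbon, 2 nitrogen; one six-membered aromatic ring with 2 hetero atoms) in place of a group of 4 heavy atoms (4 carbon; one three-membered non-aromatic ring of carbon only), on an oxygen on an aromatic ring). Among the measured compounds shown here, no measured step swaps a cyclopropylmethyl for such a ring, so the step from compound 1 to compound 3 bears on it only by showing that a change of the group on the oxygen on the aromatic ring can move the number a great deal. Compound 2 also carries a six-membered aromatic ring on that oxygen, and its value of 25.1 nM stands far below the number of compound 3, which points to a large fall. Compound 4 is therefore expected to give 40 nM, with a range from 10 nM to 160 nM. That estimate means that a 40-fold lower number from compound 3 to compound 4 (1.60 log units; beyond the scatter) is expected.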

Compound 4, half-maximal inhibitory concentration: 3160 nM
Compound 4: middle estimate off by 79-fold (1.90 log units), on the low side; measured number outside the range, above it.
By their numbers in this assay, from the lowest: compound 2; then compounds 3 and 4 (each within the scatter of the next); then compound 1.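

In this assay, the ring on the saturated chain carbon proves decisive: with the rest of the molecule unchanged, pyrimidin-2-yl in place of 5-fluoropyridin-2-yl gives (a 130-fold higher number from compound 2 to compound 4 (2.10 log units; beyond the scatter)), so a six-membered aromatic ring there does not by itself secure the low number of compound 2. On the oxygen on the aromatic ring, the group of compound 4 stands level with cyclopropylmethyl (a 2.0-fold higher number from compound 3 to compound 4 (0.30 log units; within the scatter)), yet both lie well under the open chain of compound 1, as the step to the pyrimidine shows (a 16-fold lower number from compound 1 to compound 4 (1.20 log units; beyond the scatter)). Nothing available explains why the two rings differ so widely.

Open, on these data alone, is whether that gap follows the fluorine, the ring nitrogens or both, on which a plain phenyl or pyridin-2-yl on the same carbon would bear. As far as these compounds go, the part played by the defined stereocentre also remains open, as compounds 2 and 4 show only one form.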